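This account rests on a few compounds, and the source may have more. Where it says the series, first, only, none or still open, it means among the compounds named here.

Measured so far in a functional assay (aorta) for inhibition, with Rattus norvegicus as the target; on this read-out lower numbers stand for stronger inhibition and higher numbers for weaker inhibition:
- Compound 1 `O=C(O)CCCCCNS(=O)(=O)c1ccccc1`: > 140000 nM, a limit of the assay and not a number
- Compound 2 `O=C(O)CCCCCCCCNS(=O)(=O)c1ccccc1`: 1600 nM

Going by the values given here, compound 2 holds the only actual number so far. Compound 3 `O=C(O)CCCCCCCCCCCNS(=O)(=O)c1ccccc1` differs from it as follows: 3-carboxypropyl in place of carboxy on a saturated chain carbon, eight bonds along the chain from a sulfonamide nitrogen. The same swap, made five bonds along the chain from a sulfonamide nitrogen, gave an at least 87-fold lower number from compound 1 to compound 2 (1.94 log units; beyond the scatter). Among the compounds with values here, this is the only measured step that bears on the change, and a single step cannot show whether the trend continues. A much smaller move in the same direction is therefore expected, with a reversal still possible. The expected move is a 1.6-fold lower number from compound 2 to compound 3 (0.20 log units; within the scatter). The estimate for compound 3 is 1000 nM, with an expected range of 150 nM to 7000 nM.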

Compound 3, half-maximal inhibitory concentration: 6400 nM
The estimate for compound 3 lay 6.4-fold (0.81 log units) below the measured number; low and high end bracket the measured number.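

In this assay, lengthening the chain by the same change, 3-carboxypropyl in place of carboxy, now goes the other way, giving a 4.0-fold higher number from compound 2 to compound 3 (0.60 log units; beyond the scatter). Potency therefore does not simply rise with chain length: among these three compounds, compound 2 is the strongest. Compound 1 is a limit of the assay and not a number, so its step to compound 2 has no exact size: the limit of > 140000 nM in this assay, at which 1 of the 3 values shown sits.

Chains of intermediate length remain open, so the best length is not fixed. Going by these compounds, it is also open whether an amide or an ester could stand in place of the carboxylic acid.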